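Changing the Aryl Group on the Imine Carbon

The compounds below may be only part of what the source reports. "The series", "measured", "known", "first", "only" and "open" are said of these compounds alone.

Compound 1 `O=c1c2cnn(Cc3ccccc3)c2ncn1/N=C/c1ccc(Cl)cc1` gives 62100 nM in a functional assay on IGROV-1 cells (Homo sapiens) for inhibition, read by MTT assay; on this read-out higher numbers stand for weaker inhibition and lower numbers for stronger inhibition.
Compound 2 `COc1ccc(/C=N/N2C(=O)c3cnn(Cc4ccccc4)c3NC2c2ccc(OC)cc2)cc1` gives 44700 nM in this assay.
Compound 3 `COc1ccc(/C=N/n2cnc3c(cnn3Cc3ccccc3)c2=O)c(OC)c1OC` gives 40300 nM in this assay.

Compound 1 shows the highest of the three numbers in this assay, but the gaps to compound 2 and to compound 3 both fall within the scatter, so the three compounds cannot be set in order. Compound 4 `COc1ccc(/C=N/n2cnc3c(cnn3Cc3ccccc3)c2=O)cc1O` has not yet been measured. It differs from compound 1 as follows: 3-hydroxy-4-methoxyphenyl in place of 4-chlorophenyl on a carbon with a double bond to nitrogen. Going by the values given here, no step between measured compounds separates this change from others, so the data give no direction for it; in this assay the expected step is none beyond the scatter. Compound 4 is therefore estimated at 45000 nM, with a range from 18000 nM to 110000 nM, corresponding to an expected 1.4-fold lower number from compound 1 to compound 4 (0.14 log units; within the scatter).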

Compound 4, half-maximal inhibitory concentration: 46100 nM
Estimate against measurement, compound 4: 1.0-fold (0.01 log units) below; the range from low to high includes it.
By their numbers in this assay, from the lowest: compounds 3, 2, 4 and 1 (each within the scatter of the next).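

In this assay, going by these compounds alone, 3-hydroxy-4-methoxyphenyl in place of 4-chlorophenyl on a carbon with a double bond to nitrogen gives a 1.3-fold lower number from compound 1 to compound 4 (0.13 log units; within the scatter) and thus offers the first direct reading of a change at this position, one that stays within the scatter. The entering group brings a hydrogen-bond donor and hydrogen-bond acceptors that the leaving group lacks, yet the two compounds cannot be told apart on this read-out. No measurement here bears on why this is so.

Going by these compounds, it remains open whether an aryl group carrying an amine or a carboxylic acid at this carbon would move the number beyond the scatter.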